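Piperidine substituent change in the glucose tolerance series

The source may report more compounds than this note shows. Statements on the series, on what has been measured and on what is new or still open speak of the compounds shown alone.

Within the data shown here, compound 2 `O=S1(=O)Cc2nc(-c3cc(F)c(Cl)cc3F)nc(N3CCC(O)CC3)c2C1` gives 1 mg/kg in a functional assay on the whole organism (blood, strain ICR) with Mus musculus as the target, in the glucose tolerance test, with a stated time of 30 min (on this read-out higher numbers stand for an effect only at larger amounts of compound and lower numbers for an effect already at smaller amounts), the highest of the two numbers so far; compound 1 `NC(=O)CC1CCN(c2nc(-c3cc(F)c(Cl)cc3F)nc3c2CS(=O)(=O)C3)CC1` gives 0.1 mg/kg. Among the measured compounds shown here, the one measured step bearing on this, a 10-fold higher number from compound 1 to compound 2 (1.00 log units; beyond the scatter), is a modest increase. Compound 3 `CN(C)C(=O)C1CCN(c2nc(-c3cc(F)c(Cl)cc3F)nc3c2CS(=O)(=O)C3)CC1` carries dimethylcarbamoyl in place of hydroxy on a saturated ring carbon. Returning an amide to that carbon, though a different one from compound 1, is expected to pull the number back down, an estimated 3.3-fold lower number from compound 2 to compound 3 (0.52 log units; beyond the scatter), but not fully, since the dimethylcarbamoyl group lacks the donor of compound 1's carbamoylmethyl. Compound 3 is therefore estimated at 0.3 mg/kg, with a range from 0.1 mg/kg to 1 mg/kg.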

Compound 3, minimum effective dose in the Mus musculus assay: 1 mg/kg
The estimate for compound 3 lay 3.3-fold (0.52 log units) below the measured number; low and high end bracket the measured number.
By their numbers in the Mus musculus assay, from the lowest: compound 1; then compounds 2 and 3 (each within the scatter of the next).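

In the Mus musculus assay, no change at the digits printed from compound 2 to compound 3 (within the scatter), and a 10-fold higher number from compound 1 to compound 3 (1.00 log units; beyond the scatter), so at this saturated ring carbon dimethylcarbamoyl matches hydroxy and does not reproduce the number of carbamoylmethyl. In a physicochemical assay for solubility, with a stated time of 20 h, at pH 6.8 (on this read-out lower numbers stand for lower solubility and higher numbers for higher solubility), compound 2 gives 91000 nM. In the physicochemical assay compound 3 gives > 100000 nM, which is a limit of the assay, so the step to it cannot be read: the limit of > 100000 nM in the physicochemical assay, at which 1 of the 2 values shown sits.

From the compounds shown here alone, whether the lower number of compound 1 goes with the chain of carbamoylmethyl or with its unsubstituted amide stays open. An unsubstituted carbamoyl on the same carbon, or a carboxylic acid on a longer chain, would bear on this.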